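Replacing the Amide Side Group of Compound 2

The source may report more compounds than this note shows. Statements on the series, on what has been measured and on what is new or still open speak of the compounds shown alone.

Compound 1 (`O=C(Nc1cccc(Nc2ncc(F)c(Nc3ccc(F)cc3)n2)c1)c1cnccn1`) and compound 2 (`O=C(Nc1cccc(Nc2ncc(F)c(Nc3ccc(F)cc3)n2)c1)c1ccncc1`) share one core and differ only on the carbonyl carbon. In a functional assay on A549 cells (Homo sapiens) for antiproliferative activity, read by sulforhodamine B assay, with a stated time of 3 days (on this read-out higher numbers stand for weaker inhibition of growth and lower numbers for stronger inhibition of growth), compound 1 gives 10300 nM and compound 2 gives 1650 nM as the lower of the two numbers. Among the measured compounds shown here, with pyridin-4-yl in place of pyrazin-2-yl, the record shows a 6.2-fold lower number from compound 1 to compound 2 (0.80 log units; beyond the scatter) as its only measured step.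

Compound 3 (`O=C(Nc1cc(Cl)cc(Cl)c1)c1cccc(Nc2ncc(F)c(Nc3ccc(F)cc3)n2)c1`) has not yet been measured. Its change from compound 2 is (3,5-dichlorophenyl)carbamoyl in place of ((pyridin-4-yl)carbonyl)amino on an aromatic carbon and, in short, (3,5-dichlorophenyl)carbamoyl takes the place of ((pyridin-4-yl)carbonyl)amino on an aromatic carbon. For the measured compounds named here, the single measured step bears on this only loosely, since it exchanged one ring for another and left the amide in place. It suggests that a change in this region can move the number, but it gives no direction for the new group. No step beyond the scatter is therefore firmly expected, and the estimate is a 1.2-fold higher number from compound 2 to compound 3 (0.08 log units; within the scatter) with wide uncertainty. In this assay the estimate for compound 3 is an expected 2000 nM with 500 nM to 8000 nM as its range.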

Compound 3, concentration for 50% growth inhibition: 17500 nM
Compound 3: middle estimate off by 8.8-fold (0.94 log units), on the low side; the measured number lies above the stated range.
By their numbers in this assay, from the lowest: compound 2; then compounds 1 and 3 (each within the scatter of the next).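

In this assay, putting (3,5-dichlorophenyl)carbamoyl in place of ((pyridin-4-yl)carbonyl)amino on this aromatic carbon gives an 11-fold higher number from compound 2 to compound 3 (1.03 log units; beyond the scatter), so the lower number of compound 2 does not carry over to this new group. Measured against the ((pyrazin-2-yl)carbonyl)amino group, the same entering group gives a 1.7-fold higher number from compound 1 to compound 3 (0.23 log units; within the scatter), which places compound 1 and compound 3 within the scatter of each other and leaves compound 2 as the only one of the three apart from the rest. No measurement at hand accounts for the step.

The step changes the ring and the direction of the amide together, so the compounds shown cannot say which of the two carries it; a (pyridin-4-yl)carbamoyl group or a ((3,5-dichlorophenyl)carbonyl)amino group at this place would separate them. They also leave open how a group of another kind, such as an amine or a carboxylic acid, would read at this aromatic carbon.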